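The source may report more compounds than this note shows. Statements on the series, on what has been measured and on what is new or still open speak of the compounds shown alone.

Going by the values given here, in a physicochemical assay for lipophilicity, read by HPLC, measured as chromatographic lipophilicity, at pH 7.4 (on this read-out lower numbers stand for lower lipophilicity and higher numbers for higher lipophilicity), compound 1 `O=C(C1CCCC1)N1N=CCC1c1ccccc1` gives 5.4, the highest of the three numbers measured so far. Compound 2 `O=C(C1CCN(C(=O)C(F)(F)F)CC1)N1N=CCC1c1ccccc1` gives 4.9, and compound 3 `Cc1nnc(N2CCC(C(=O)N3N=CC[C@H]3c3cc(F)cc(F)c3)CC2)o1` gives 3.6. Both lie lower than compound 1 by more than the usual scatter, and compound 3 is the furthest away. Compound 4 `O=C(c1ccccc1)N1N=CCC1c1ccccc1` has not yet been measured in this assay. It differs from compound 1 in one place, with phenyl in place of cyclopentyl on a carbonyl carbon. The rest of the structure stays the same. Among the compounds with values here, no two measured compounds differ in only one place, so the data offer no direct precedent for this exchange, and the expectation carries real uncertainty. A modest downward move is expected, slightly beyond the scatter, and the estimated change is a number 0.40 log units lower from compound 1 to compound 4 (beyond the scatter). The expected value for compound 4 is 5, within an estimated range from 4.6 to 5.4.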

Compound 4, distribution coefficient: 4.6
Beside the measured number, compound 4's estimate is 0.40 log units above it, within the range that was stated.
By their numbers in this assay, from the lowest: compound 3; then compounds 4 and 2 (each within the scatter of the next); then compound 1.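

In this assay, the exchange of cyclopentyl for phenyl on a carbonyl carbon gives the first reading from a single change in this study (a number 0.80 log units lower from compound 1 to compound 4 (beyond the scatter)). The earlier compounds shown here differ from one another in more than one place, whereas this step shows that the group at this position alone can move the read-out beyond the scatter, with the rest of the structure held the same and with no change in the counts of hydrogen-bond donors, hydrogen-bond acceptors or net charge. Nothing available explains why the number moves as it does.

From the compounds shown here alone, it remains open whether other groups on this carbonyl carbon, such as a pyridine ring or a tert-butyl group, would give a step of similar size. Going by these compounds, it is also open whether the same exchange would give a similar step when the rest of the structure is changed, as it is in compound 3.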